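A few compounds are considered here, and "the series" means these few. Any claim that something is new, unique, unknown or untested is made for them only; others in the source may bear on it.

Measured so far in an ADME assay on HepG2 cells (Homo sapiens) for cytotoxicity, read by CellTiter-Glo and resazurin assay, with a stated time of 72 h; on this read-out lower numbers stand for an effect already at smaller amounts and higher numbers for an effect only at larger amounts of compound:

- compound 1 `CCOC(=O)CCCCCOc1cccc(CN(C(=O)c2ccc(-c3cccc4ccccc34)cc2)C(C)C)c1` — compound 1 gives > 26000 nM, a limit of the assay
- compound 2 `CCOC(=O)CCCCCOc1cccc(CN(C(=O)c2ccc(-c3cccc(OCC(C)C)c3)cc2)C(C)C)c1` — compound 2 gives > 26000 nM, a limit of the assay
- compound 3 `CCOC(=O)CCCCCOc1cccc(CN(C(=O)c2ccc(-c3cccc(OCC)c3)cc2)C(C)C)c1` — compound 3 gives > 22300 nM, a limit of the assay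

All three measured compounds share the same core and differ only in the group on the aromatic carbon that carries the naphthalen-1-yl, the 3-(isobutoxy)phenyl or the 3-ethoxyphenyl. None of them returns a number in this assay: each value is a limit, as shown in the limit of > 22300 nM in this assay, at which 1 of the 3 values shown sits, and (the limit of > 26000 nM in this assay, at which 2 of the 3 values shown sit). The steps therefore cannot be read: a step that the two limits leave unreadable from compound 1 to compound 2, a step that the two limits leave unreadable from compound 1 to compound 3 and a step that the two limits leave unreadable from compound 2 to compound 3. Compound 3 thus stands with the other two at a limit, and no ordering among the three is possible.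

Compound 4 `CCOC(=O)CCCCCOc1cccc(CN(C(=O)c2ccc(-c3ccc(Cl)c(Cl)c3)cc2)C(C)C)c1` is not yet measured. It differs from compound 3 as follows: 3,4-dichlorophenyl in place of 3-ethoxyphenyl on an aromatic carbon. The measured steps bear on this only in that every change of this group so far has left the value at a limit; none of them gives a readable size or direction. No step beyond the scatter is therefore expected, and the expected step is a step that the limit leaves unreadable from compound 3 to compound 4. Compound 4 is estimated at 26000 nM, with a range from 10000 nM to 60000 nM, most likely reported as a limit again.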

Compound 4, half-maximal effective concentration: > 26000 nM
Compound 4: only a limit was reported; the forecaster's own chance of this, stated with the estimate: 70%; the middle value sits exactly at the limit.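

In this assay compound 4 gives > 26000 nM, which is a limit of the assay. Going by these compounds alone, no step can therefore be read between compound 4 and compound 1, compound 2 or compound 3. The compounds shown leave open at what concentration any of the four reaches the half-maximal effect, and whether the group on the aromatic carbon changes that concentration at all.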